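The source may report more compounds than this note shows. Statements on the series, on what has been measured and on what is new or still open speak of the compounds shown alone.

Compound 3 `COC1Cc2c(csc2-c2ccc(C)cc2)C2(CCN(Cc3ccccc3)CC2)O1` gives 2 nM in an assay on membranes from brain for displacement of a labelled ligand from Sigma non-opioid intracellular receptor 1 (Cavia porcellus), read by scintillation counting, with a stated time of 120 min (a lower number here means a stronger inhibitor, a higher number a weaker inhibitor), and holds the lowest of the three numbers; compound 2 `N#Cc1ccc(-c2scc3c2CCOC32CCN(Cc3ccccc3)CC2)cc1` gives 3.4 nM, a gap within the scatter, while compound 1 `c1ccc(CN2CCC3(CC2)OCCc2c3csc2-c2ccccc2)cc1` gives 4.5 nM, a gap beyond it. Among the measured compounds shown here, the only measured single-point step, a 1.3-fold lower number from compound 1 to compound 2 (0.12 log units; within the scatter), replaces hydrogen with cyano on an aromatic carbon and stays within the scatter. Compound 4 `COC1Cc2c(csc2-c2cccnc2)C2(CCN(Cc3ccccc3)CC2)O1` carries pyridin-3-yl in place of 4-methylphenyl on an aromatic carbon. For the measured compounds named here, no measured step swaps a ring of carbon only for a ring with a nitrogen, so the basis is thin; the one aromatic-ring change in hand was small. A modest move toward a higher number is therefore expected, about a 2.0-fold higher number from compound 3 to compound 4 (0.30 log units; within the scatter). Compound 4 is expected at 4 nM, with a range of 1.5 nM to 12 nM.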

Compound 4, inhibition constant: 2.2 nM
For compound 4 the middle estimate is 1.8-fold (0.26 log units) above the measured one; measured number inside the range.
By their numbers in this assay, from the lowest: compounds 3, 4, 2 and 1 (each within the scatter of the next, the first and the last beyond it).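

In this assay, pyridin-3-yl in place of 4-methylphenyl on the aromatic carbon next to the ring sulfur stays within the scatter (a 1.1-fold higher number from compound 3 to compound 4 (0.04 log units; within the scatter)). Among the compounds shown here, compounds 1, 2 and 3 all carry a ring of carbon only here, so compound 4 is the first sign that a ring nitrogen, with its hydrogen-bond acceptor, is accepted at this position on the core of compound 3. No evidence on why the swap leaves the number within the scatter is available.

Open is whether the nitrogen's place in the ring matters, as pyridin-2-yl and pyridin-4-yl are not among the compounds shown. Also open, on these data alone, is how an amine or a carboxylic acid on this ring would read.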